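Ester-to-acid step at the cinnamate terminus, compound 2 to 4

This account rests on a few compounds, and the source may have more. Where it says the series, first, only, none or still open, it means among the compounds named here.

Compound 1 `Cc1nc(C)c(C(=O)Oc2ccccc2/C=C/C(=O)O)nc1C` gives 64.9% in a functional assay on EA.hy 926 cells (Homo sapiens) for cytotoxicity, read by MTT assay, with stated times of 24 h and 12 h, tested at 50 uM; a higher number here means a stronger effect of the compound at the concentration tested, a lower number a weaker effect. Compound 3 `Cc1nc(C)c(C(=O)Oc2ccc(Cl)cc2/C=C/C(=O)O)nc1C` differs from compound 1 by chloro in place of hydrogen on an aromatic carbon. In this assay compound 3 gives 23.7%. That change reads a number 41.2 percentage points lower from compound 1 to compound 3 (beyond the scatter). Compound 2 `CCOC(=O)/C=C/c1cc(OC)c(OC(=O)c2nc(C)c(C)nc2C)c(OC)c1` gives -13.6% and stands lowest of the three measured numbers, below compound 3 and well below compound 1, both gaps beyond the scatter.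

Compound 4 `COc1cc(/C=C/C(=O)O)cc(OC)c1OC(=O)c1nc(C)c(C)nc1C` is not yet measured. It differs from compound 2 by hydrogen in place of ethyl on an oxygen next to a carbonyl group. Within the data shown here, no measured pair shares this change; the single measured step concerns chloro for hydrogen and does not bear on it. What can be said is that compounds 1 and 3, both carrying the 2-carboxyethenyl group rather than the 2-(ethoxycarbonyl)ethenyl group, sit well above compound 2, though they also lack the two methoxy groups of compound 2 and compound 4, so the comparison is loose.

On this basis compound 4 is expected to lie above compound 2, with wide uncertainty. The estimated step of a number 38.6 percentage points higher from compound 2 to compound 4 (beyond the scatter) is therefore an increase. Compound 4 is expected to give about 25%, with a range from -5% to 55%.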

Compound 4, a percentage reported as activity, at one concentration (the size of the read-out at that concentration, not a potency): 96.6%
The estimate for compound 4 lay 71.6 percentage points below the measured number; measured number above the stated range.
By their numbers in this assay, from the lowest: compound 2; then compound 3; then compound 1; then compound 4.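

Replacing ethyl with hydrogen on an oxygen next to a carbonyl group, which turns 2-(ethoxycarbonyl)ethenyl into 2-carboxyethenyl, gives a number 110.2 percentage points higher from compound 2 to compound 4 (beyond the scatter) in this assay. Among these compounds, the only earlier step, chloro for hydrogen on an aromatic carbon, said nothing about this place; the new step shows that this single change, with only an ethyl group of 2 heavy atoms leaving, separates the lowest and the highest of the four numbers. Nothing in the available data accounts for the size of this step.

From the compounds shown here alone, it remains open how a methyl ester, a longer-chain ester or a primary amide at this carbonyl would read, and so whether the number follows the free carboxylic acid specifically or simply the loss of ethyl. Also open, going by these compounds, is whether a step of this size would carry over to a partner of compound 1 or compound 3, whose cores lack the two methoxy groups, and how the single-concentration read-out would translate into a potency.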